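Indole series: removing the ring fluoro of compound 3

The source may hold more compounds than are shown below. What is called first, only, known or untested is meant among the compounds shown, and "the series" means these compounds.

Three compounds of the series have numbers in a functional assay on the whole organism for inhibition, with Rattus norvegicus as the target; a higher number here means that more compound is needed for the effect, a lower number that less compound is needed. Compound 1 `O=C1NCCN1CCN1CCC(c2cn(-c3ccc(F)cc3)c3ccc(C(F)(F)F)cc23)CC1` gives 0.11 umol/kg. Compound 2 `O=C1NCCN1CCCN1CCC(c2cn(-c3ccc(F)cc3)c3ccc(Cl)cc23)CC1` gives 1.8 umol/kg. Compound 3 `CN1CC=C(c2cn(-c3ccc(F)cc3)c3ccc(F)cc23)CC1` gives 0.15 umol/kg. Compound 3 stands second highest of the three: its nearest neighbour is compound 1, a gap within the scatter, and its furthest is compound 2, a gap beyond the scatter. No two of these three differ in a single place, so none of the gaps can be read as the effect of one change.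

The step under consideration goes from compound 3 to compound 4 `CN1CC=C(c2cn(-c3ccc(F)cc3)c3ccccc23)CC1`. The difference between them is hydrogen in place of fluoro on an aromatic carbon. The fluorine that leaves sits on an aromatic carbon of a six-membered aromatic ring of carbon only, part of a fused system of two rings; a hydrogen atom enters there.

Among the measured compounds shown here, no measured pair in this set isolates this change, so the expected step in this assay is taken as small, at most a modest rise in the dose, and it may well stay within the scatter. The estimate for compound 4 is 0.3 umol/kg, with a range from 0.1 umol/kg to 1 umol/kg, which corresponds to an expected step of a 2.0-fold higher number from compound 3 to compound 4 (0.30 log units; within the scatter).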

Compound 4, dose for half-maximal effect: 0.15 umol/kg
Estimate against measurement, compound 4: 2.0-fold (0.30 log units) above, and the stated range covers the measured number.
By their numbers in this assay, from the lowest: compounds 1, 3 and 4 (each within the scatter of the next); then compound 2.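

Working notes on the ring position: in this assay, hydrogen in place of fluoro on an aromatic carbon of the fused system gives no change at the digits printed from compound 3 to compound 4 (within the scatter), and this is the only step in the series so far that isolates a single place. Among the compounds shown here, for this pair, the ring fluoro is therefore not required to hold the dose in this whole-organism read-out, a statement that the earlier compounds, which differ from one another in more than one place, could not support and that applies only to the core shared by compound 3 and compound 4. Nothing available accounts for the absence of a measurable step at this carbon.

On these data alone, whether a larger or different group at this carbon, such as methoxy, nitrile, chloro or trifluoromethyl, would leave the dose equally unmoved on the core of compound 4 remains open. Also open, as far as these compounds go, is whether hydrogen in place of a substituent at this carbon would be as well tolerated with the longer side chains of compound 1 and compound 2, which carry a cyclic urea instead of the methyl group on nitrogen.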